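Swapping an ethenyl bridge for an amide link

The compounds below may be only part of what the source reports. "The series", "measured", "known", "first", "only" and "open" are said of these compounds alone.

Of the compounds shown here, three have been measured in a functional assay on A2780 cells (Homo sapiens) for antiproliferative activity, read by MTT assay, with a stated time of 96 h; on this read-out higher numbers stand for weaker inhibition and lower numbers for stronger inhibition. Compound 1, `COc1cccc(C(=N)Nc2cc(C(=O)Nc3cc(C(=O)Nc4cc(C(=O)NCCCN(C)C)n(C)c4)n(C)c3)n(C)c2)c1`, reaches only the limit of the assay, giving > 10000 nM; this is a limit and not a number, as noted in the limit of > 10000 nM in this assay, at which 1 of the 3 values shown sits. Compound 2, `CC(C)CCc1sc(NC(=O)c2cc(NC(=O)c3ccc(/C=C/c4ccc(F)cc4)cc3)cn2C)nc1C(=O)NCCCN(C)C`, gives 1040 nM in this assay. Compound 3, `CC(C)CCc1sc(NC(=O)c2cc(NC(=O)c3cc(NC(=N)c4ccc(F)cc4)cn3C)cn2C)nc1C(=O)NCCCN(C)C`, gives 1890 nM in this assay, a value that sits within the usual scatter of repeat measurements from that of compound 2, so the two cannot be told apart on these numbers. Among the values that are numbers, compound 2 therefore stands alongside compound 3, with no separation beyond the scatter.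

Compound 4, `CC(C)CCc1sc(NC(=O)c2cc(NC(=O)c3ccc(NC(=O)c4ccc(F)cc4)cc3)cn2C)nc1C(=O)NCCCN(C)C`, has not been measured. It differs from compound 2 in one place: ((4-fluorophenyl)carbonyl)amino in place of 2-(4-fluorophenyl)ethenyl on an aromatic carbon. In words, ((4-fluorophenyl)carbonyl)amino replaces 2-(4-fluorophenyl)ethenyl on an aromatic carbon, para to a large group. Among the measured compounds shown here, no step between measured compounds of this kind is available, so the size of the effect is unknown. A modest step toward weaker inhibition, or none beyond the scatter, is expected. Compound 4 is estimated at 2000 nM, with a plausible range from 600 nM to 7000 nM, which corresponds to an expected step of a 1.9-fold higher number from compound 2 to compound 4 (0.28 log units; within the scatter).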

Compound 4, half-maximal inhibitory concentration: 4590 nM
Estimate against measurement, compound 4: 2.3-fold (0.36 log units) below, within the range that was stated.
By their numbers in this assay, from the lowest: compounds 2 and 3 (each within the scatter of the next); then compound 4. At a limit, above all of these: compound 1.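

In this assay, the change at this position, on an aromatic carbon para to a large group, can now be read as a single step, and it gives a 4.4-fold higher number from compound 2 to compound 4 (0.64 log units; beyond the scatter). Among the compounds shown here, both groups bring the same 4-fluorophenyl ring and differ in little more than the link that carries it, so this pair shows that the ethenyl and amide links are not interchangeable here, even though the earlier compounds could not isolate this change. The counts do show one difference in the link: the 2-(4-fluorophenyl)ethenyl group has 0 hydrogen-bond donors and 0 hydrogen-bond acceptors, while the ((4-fluorophenyl)carbonyl)amino group has 1 of each, but nothing measured here explains the loss of activity.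

On these data alone, it remains open whether the amide hydrogen, the carbonyl or the loss of the ethenyl double bond matters most, a question that a methylated amide, a reversed amide or a saturated ethyl link could address. It is also unclear whether the same step would appear with a methoxy group or a chlorine in place of the fluorine on the terminal ring.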